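This account rests on a few compounds, and the source may have more. Where it says the series, first, only, none or still open, it means among the compounds named here.

The study covers a small set of compounds built on one shared core, varied at two places. Compound 1 `CCCCCCC(CCO)n1cnc2c(Cl)ncnc21` serves as the point of reference. In a functional assay on SW480 cells (Homo sapiens) for antiproliferative activity, read by MTT assay, with a stated time of 48 h (on this read-out lower numbers stand for stronger inhibition and higher numbers for weaker inhibition), compound 1 gives 16700 nM. Compound 2 `CCCCCCC(CCO)n1cnc2c(OC)ncnc21` differs from compound 1 by methoxy in place of chloro on an aromatic carbon. In this assay compound 2 reaches only the limit of the assay, > 50000 nM, and no number. The resulting step, an at least 2.9-fold higher number from compound 1 to compound 2 (0.47 log units; beyond the scatter), rests on (the limit of > 50000 nM in this assay, at which 1 of the 3 values shown sits). Compound 3 `CCCCCCCCC(CCO)n1cnc2c(Cl)ncnc21` differs from compound 1 by ethyl in place of hydrogen on a saturated chain carbon, seven bonds along the chain from an aromatic nitrogen. In this assay compound 3 gives 1370 nM, and the step of a 12-fold lower number from compound 1 to compound 3 (1.09 log units; beyond the scatter) is the largest seen among these compounds. Going by the values given here, of the numbers known so far, compound 3 holds the lowest.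

Compound 4 `CCCCCCCCC(CCO)n1cnc2c(OC)ncnc21` has not yet been measured. Among the compounds with values here, it differs from compound 3 by methoxy in place of chloro on an aromatic carbon, which is the same change as the one from compound 1 to compound 2, made at the same place on the same core. For compound 4 the expected step is a 5.8-fold higher number from compound 3 to compound 4 (0.77 log units; beyond the scatter), because an at least 2.9-fold higher number from compound 1 to compound 2 (0.47 log units; beyond the scatter) gives only a floor to the loss and the true step may well be larger. For compound 4 in this assay the estimate is 8000 nM, with a plausible range from 3000 nM to 30000 nM, and a fair chance that only a limit is reported.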

Compound 4, half-maximal inhibitory concentration: 24600 nM
Estimate against measurement, compound 4: 3.1-fold (0.49 log units) below; low and high end bracket the measured number.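

In this assay methoxy in place of chloro raises the number on both cores, and on the core with the added ethyl the step can be read in full, an 18-fold higher number from compound 3 to compound 4 (1.25 log units; beyond the scatter), which sets the two cores side by side as follows: the same change on two cores in this assay, an at least 2.9-fold higher number (0.47 log units; beyond the scatter) from compound 1 to compound 2 and an 18-fold higher number (1.25 log units; beyond the scatter) from compound 3 to compound 4; the limit leaves it open whether they differ The ethyl change, read on the methoxy compounds, gives an at least 2.0-fold lower number from compound 2 to compound 4 (0.30 log units; that floor lies within the scatter), and this stands beside its counterpart on the chloro compounds as follows: the same change on two cores in this assay, a 12-fold lower number (1.09 log units; beyond the scatter) from compound 1 to compound 3 and an at least 2.0-fold lower number (0.30 log units; that floor lies within the scatter) from compound 2 to compound 4; the limit leaves it open whether they differ The direction of the methoxy change thus carries from one core to the other, but whether its size carries as well cannot be said, because compound 2 stands only at a limit of the assay: the limit of > 50000 nM in this assay, at which 1 of the 4 values shown sits.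

The compounds shown hold only chloro and methoxy on that aromatic carbon, which leaves open how an amine or a thioether in the same place would read in this assay, and whether either would follow the same direction on both cores. They also leave open whether a longer chain would lower the number further, and what a carboxylic acid in place of the hydroxyl would do.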